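The compounds below may be only part of what the source reports. "The series", "measured", "known", "first", "only" and "open" are said of these compounds alone.

Of the compounds shown here, three built on related cores have been measured in a functional assay on SF-268 cells (Homo sapiens) for inhibition, read by sulforhodamine B assay, with a stated time of 48 h; on this read-out lower numbers stand for stronger inhibition of growth and higher numbers for weaker inhibition of growth. Compound 1, `N#CCC1=NN=C(c2ccc(Br)cc2)C(CC(=O)c2ccc([N+](=O)[O-])cc2)O1`, gives 18500 nM. Compound 2, `N#CCC1=NN=C(c2ccc([N+](=O)[O-])cc2)C(CC(=O)c2ccc([N+](=O)[O-])cc2)O1`, gives 2000 nM. Compound 3, `N#CCC1=NN=C(c2ccc(Br)cc2)C(Br)O1`, gives 32000 nM; how its core differs from that of compound 1 is not broken down here.

Compounds 1 and 2 differ in one place only, (nitro in place of bromo on an aromatic carbon), and that change brought a 9.3-fold lower number from compound 1 to compound 2 (0.97 log units; beyond the scatter).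

The same change is now made on the core of compound 3 to give compound 4, `N#CCC1=NN=C(c2ccc([N+](=O)[O-])cc2)C(Br)O1`: here too (nitro in place of bromo on an aromatic carbon). Since the surroundings of the change are described in the same words in both pairs, the expectation for this step rests on the earlier one, with the caution that it is seen only once so far and is transferred across a different core. Compound 4 is therefore expected to show a step of about an 8.0-fold lower number from compound 3 to compound 4 (0.90 log units; beyond the scatter) in this assay, because the matching change gave a 9.3-fold lower number from compound 1 to compound 2 (0.97 log units; beyond the scatter). On that basis compound 4 is estimated to give 4000 nM, with a plausible range from 1500 nM to 12000 nM.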

Compound 4, concentration for 50% growth inhibition: 6700 nM
Compound 4: the middle estimate sits 1.7-fold (0.22 log units) below what was measured; the range from low to high includes it.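

In this assay, putting nitro in place of bromo on the aromatic carbon again lowered the number on the second core, with a 4.8-fold lower number from compound 3 to compound 4 (0.68 log units; beyond the scatter), so the change pointed towards stronger inhibition of growth on both cores. Set side by side, the two steps cannot be told apart in size: the same change on two cores in this assay, a 9.3-fold lower number (0.97 log units; beyond the scatter) from compound 1 to compound 2 and a 4.8-fold lower number (0.68 log units; beyond the scatter) from compound 3 to compound 4, 1.9-fold (0.29 log units) apart, within the scatter of two such steps. This shows that the change carried over from one core to the other in these two pairs, but two pairs in a single cell line do not show that it would hold on other cores or in other cells, and they do not explain why the number falls.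

The compounds shown leave open how other groups on that aromatic carbon, such as an amine or a carboxylic acid, would compare with nitro and bromo. From the compounds shown here alone, it also remains open whether a longer chain carrying the nitrile would change the size of the step.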